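The compounds below may be only part of what the source reports. "The series", "measured", "known", "first", "only" and "open" are said of these compounds alone.

Working notes on the series. In a functional assay on NCI-H1299 cells (Homo sapiens) for antiproliferative activity, read by CCK-8 assay, with a stated time of 72 h (on this read-out higher numbers stand for weaker inhibition and lower numbers for stronger inhibition), compound 1 (`CCOc1cc(C(C)(C)C)ccc1C1=NC(c2ccc(Cl)cc2)C(c2ccc(Cl)cc2)N1C(=O)NCCCCCCCC(=O)Nc1ccccc1N`) gives 19600 nM, compound 2 (`CCOc1cc(C(C)(C)C)ccc1C1=NC(c2ccc(Cl)cc2)C(c2ccc(Cl)cc2)N1C(=O)N1CCN(CCCCCC(=O)NO)CC1`) gives 9390 nM and compound 3 (`CCOc1cc(C(C)(C)C)ccc1C1=NC(c2ccc(Cl)cc2)C(c2ccc(Cl)cc2)N1C(=O)NCCCCCCC(=O)Nc1ccccc1N`) gives 17500 nM. Compound 3 lies within the scatter of both compound 1 and compound 2, so it holds no distinct rank among the three.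

Compound 4 (`CCOc1cc(C(C)(C)C)ccc1C1=NC(c2ccc(Cl)cc2)C(c2ccc(Cl)cc2)N1C(=O)NCCCCC(=O)Nc1ccccc1N`) differs from compound 3 in one place: (2-aminophenyl)carbamoyl in place of 2-((2-aminophenyl)carbamoyl)ethyl on a saturated chain carbon, four bonds along the chain from an amide-type nitrogen. In words, (2-aminophenyl)carbamoyl stands in place of 2-((2-aminophenyl)carbamoyl)ethyl on a saturated chain carbon, four bonds along the chain from an amide-type nitrogen.

Going by the values given here, one measured step bears on this, a replacement of the same kind: a 1.1-fold lower number from compound 1 to compound 3 (0.05 log units; within the scatter), which stays within the scatter. Among the compounds with values here, no measured step covers a replacement of this size, so the support is thin and the range is kept wide. No change beyond the scatter is expected in this assay, and no direction is favoured. The estimated change is a 1.1-fold lower number from compound 3 to compound 4 (0.04 log units; within the scatter). For compound 4 the estimated value is 16000 nM, with an expected range from 8000 nM to 30000 nM.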

Compound 4, half-maximal inhibitory concentration: 15600 nM
Estimate against measurement, compound 4: 1.0-fold (0.01 log units) above, and the stated range covers the measured number.
By their numbers in this assay, from the lowest: compounds 2, 4, 3 and 1 (each within the scatter of the next, the first and the last beyond it).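

In this assay the replacement of 2-((2-aminophenyl)carbamoyl)ethyl by (2-aminophenyl)carbamoyl, on a saturated chain carbon, four bonds along the chain from an amide-type nitrogen, gives a 1.1-fold lower number from compound 3 to compound 4 (0.05 log units; within the scatter). The earlier step, a 1.1-fold lower number from compound 1 to compound 3 (0.05 log units; within the scatter), covered only a smaller replacement on this chain; the shorter chain of compound 4 extends that reading, and this larger replacement also stays within the scatter, so across compounds 1, 3 and 4 the chain length tested makes no distinction on this read-out. No supporting measurement bears on this result.

As far as these compounds go, it remains open whether a carboxylic acid in place of (2-aminophenyl)carbamoyl at the chain end, or a chain shorter than that of compound 4, would give a step beyond the scatter.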